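The source may hold more compounds than are shown below. What is called first, only, known or untested is meant among the compounds shown, and "the series" means these compounds.

Compound 1 `CC(=O)c1nc([N+](=O)[O-])c(Sc2cccc(Cl)c2Cl)s1`: 9930 nM
Compound 2 `CCCC(=O)OC(C)c1nc([N+](=O)[O-])c(Sc2c(Cl)cncc2Cl)s1`: 4490 nM
Compound 3 `COc1cccc(Sc2sc(C(C)=O)nc2[N+](=O)[O-])c1`: > 50000 nM

Of the compounds shown here, three on the shared core have been read in an assay on isolated protein for inhibition of ubiquitin carboxyl-terminal hydrolase 7 (Homo sapiens), read by fluorescence, with stated times of 30 min and 3 h; on this read-out higher numbers stand for weaker inhibition and lower numbers for stronger inhibition. Compound 2 stands at the lowest of the two numbers, 4490 nM. Its nearest neighbour is compound 1 with 9930 nM, a gap that lies beyond the usual scatter of this assay. For compound 3 the assay reports only a limit, > 50000 nM, and no number; that value is the limit of > 50000 nM in this assay, at which 1 of the 3 values shown sits.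

The piece now follows one step away from compound 2, to compound 4 `CC(O)c1nc([N+](=O)[O-])c(Sc2c(Cl)cncc2Cl)s1`, which has not yet been measured in this assay. The change is hydrogen in place of propylcarbonyl on an oxygen on a saturated carbon. For the measured compounds named here, no pair of measured compounds spans this difference, so the expectation rests on compound 2 alone and on the absence of any measured step of this kind. A hydrogen in place of propylcarbonyl on the oxygen is expected to shift this assay modestly, if at all, toward a higher number, though a change within the scatter would not surprise. Compound 4 is therefore estimated at 7000 nM, with a range from 2500 nM to 20000 nM. This amounts to an expected step of a 1.6-fold higher number from compound 2 to compound 4 (0.19 log units; within the scatter).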

Compound 4, half-maximal inhibitory concentration: 6950 nM
Estimate against measurement, compound 4: 1.0-fold (0.00 log units) above; measured number inside the range.
By their numbers in this assay, from the lowest: compounds 2, 4 and 1 (each within the scatter of the next, the first and the last beyond it). At a limit, above all of these: compound 3.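

In this assay, hydrogen in place of propylcarbonyl on an oxygen on a saturated carbon gives a 1.5-fold higher number from compound 2 to compound 4 (0.19 log units; within the scatter), so this first measured step at the position does not separate the two compounds. Until now, the position rested on compound 2 alone; the pair now shows that the 1-((propylcarbonyl)oxy)ethyl group, with its five heavy atoms and its double bond, and the 1-hydroxyethyl group read alike here, at least on this single pair. The values give no reason for this, and nothing measured on these compounds speaks to why the propylcarbonyl group can go without a step beyond the scatter.

What the compounds shown leave open is whether this holds for other groups on that oxygen, such as a methyl group or a longer acyl chain, or for an amine in place of the hydroxy group. They also leave open whether the same step would read alike with the other aromatic groups that compound 1 and compound 3 carry on the sulfur.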